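Phenyl substituent changes in a series of oxazolidinone amides

The source may report more compounds than this note shows. Statements on the series, on what has been measured and on what is new or still open speak of the compounds shown alone.

compound 1 `O=C(CCCCCc1ccc(O)c(F)c1)N1CCOC1=O` 160 nM
compound 2 `O=C(CCCCCc1cccc(O)c1)N1CCOC1=O` 8640 nM
compound 3 `O=C(CCCCCc1ccc(I)cc1)N1CCOC1=O` > 20000 nM

In an assay on HEK293 cells for inhibition of N-acylethanolamine-hydrolyzing acid amidase (Rattus norvegicus), read by LC-MS, with a stated time of 30 min (a lower number here means a stronger inhibitor, a higher number a weaker inhibitor), compound 1 gives 160 nM and compound 2 gives 8640 nM. Compound 3 gives > 20000 nM, a limit of the assay rather than a number; (the limit of > 20000 nM in this assay, at which 1 of the 3 values shown sits). Among the two numbers compound 2 stands highest, with compound 1 well below it, a gap beyond the scatter.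

Compound 4 `Cc1cccc(CCCCCC(=O)N2CCOC2=O)c1` has not been measured. It differs from compound 2 by methyl in place of hydroxy on an aromatic carbon, sitting meta to a large group. For the measured compounds named here, no measured pair shows this change. Compound 2 already holds the highest number. Compound 3, which carries no hydroxy, reaches only a limit. A step from compound 2 to compound 4 toward a higher number, beyond the scatter and possibly into a limit, is expected. Compound 4 is estimated at 18000 nM (range 5000 nM to 50000 nM), the expected step being a 2.1-fold higher number from compound 2 to compound 4 (0.32 log units; beyond the scatter).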

Compound 4, half-maximal inhibitory concentration: 350 nM
Compound 4: the middle estimate sits 51-fold (1.71 log units) above what was measured; measured number below the stated range.
By their numbers in this assay, from the lowest: compound 1; then compound 4; then compound 2. At a limit, above all of these: compound 3.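

In this assay, the replacement of hydroxy by methyl on an aromatic carbon, meta to a large group, gives a 25-fold lower number from compound 2 to compound 4 (1.39 log units; beyond the scatter). This position therefore does not need the hydroxy, or the hydrogen-bond donor and acceptor it carries, for a low number, and methyl is much the better of the two groups here. Nothing on hand bears on the cause of this step.

On these data alone, whether methoxy, ethyl or chlorine at this place would match methyl remains open. So does whether the step holds with a shorter or longer chain in the series.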